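From compound 3 to compound 4: cyclopropylmethyl on nitrogen

The compounds below may be only part of what the source reports. "The series", "measured", "known", "first", "only" and "open" are said of these compounds alone.

In an ADME assay on Huh-7 cells (Homo sapiens) for cytotoxicity, with a stated time of 72 h (a lower number here means that less compound is tolerated, a higher number that more compound is tolerated), compound 3 (`CC(C)CC(C)n1nc(-c2cccs2)c(O)c(C2=NS(=O)(=O)c3cc(NS(C)(=O)=O)ccc3N2)c1=O`) gives > 33000 nM, which is a limit and not a number. Compound 2 (`CS(=O)(=O)Nc1ccc2c(c1)S(=O)(=O)N=C(c1c(O)c(-c3cccs3)nn(CCC3CC3)c1=O)N2`) also gives only a limit, > 33000 nM. Compound 1 (`CCC(C)CCn1nc(-c2cccs2)c(O)c(C2=NS(=O)(=O)c3cc(NS(C)(=O)=O)ccc3N2)c1=O`) likewise gives only a limit, > 1000 nM. Compound 3 thus has no numerical value to start from, and it shares its limit with compound 2.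

Compound 4 (`CS(=O)(=O)Nc1ccc2c(c1)S(=O)(=O)N=C(c1c(O)c(-c3cccs3)nn(CC3CC3)c1=O)N2`) differs from compound 3 as follows: cyclopropylmethyl in place of 1,3-dimethylbutyl on an aromatic nitrogen. Cyclopropylmethyl takes the place of 1,3-dimethylbutyl on an aromatic nitrogen.

The measured steps bearing on this change are a step that the two limits leave unreadable from compound 2 to compound 3 and a step that the two limits leave unreadable from compound 1 to compound 3. Neither supplies a size to carry over. The expectation rests mainly on compound 2 at > 33000 nM, a limit, with 2-cyclopropylethyl on the same nitrogen where compound 4 has cyclopropylmethyl.

No step beyond the usual scatter is expected in this assay, and no direction is favoured, so the estimated change is a number no higher from compound 3 to compound 4 (the limit leaves the size open). The expected value for compound 4 is 33000 nM, within an estimated range of 10000 nM to 60000 nM.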

Compound 4, half-maximal cytotoxic concentration: > 1000 nM
Compound 4: only a limit was reported (the forecaster's own chance of this, stated with the estimate: 85%); the middle value is on the limit's open side.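

In this assay compound 4 gives > 1000 nM, a limit and not a number. Compound 1, compound 2 and compound 3 also carry only limits, so no step among these four compounds can be read. From the compounds shown here alone, what stays open is the actual tolerated concentration of each compound, and whether changing the group on the aromatic nitrogen shifts it at all.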